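Propoxy in place of isopropyl: expected inhibition of compound 3

The compounds below may be only part of what the source reports. "The series", "measured", "known", "first", "only" and "open" are said of these compounds alone.

For the measured compounds named here, compound 2 `CC(C)c1ccc(S(=O)(=O)NC(=O)Nc2ccc(Cl)cc2)s1` gives 63% in a functional assay on the whole organism (6C3HED cells, Mus musculus) for inhibition, at a dose of 300 mg/kg by the oral route (on this read-out higher numbers stand for more inhibition at the one dose given (going by the name of the read-out) and lower numbers for less inhibition), the lowest of the two numbers measured so far; the nearest is compound 1 `O=C(Nc1ccc(Cl)cc1)NS(=O)(=O)c1ccc(Cl)s1`, which in this assay gives 89%. Going by the values given here, the only measured step, a number 26 percentage points lower from compound 1 to compound 2 (beyond the scatter), ran downward beyond the scatter. Compound 3 `CCCOc1ccc(S(=O)(=O)NC(=O)Nc2ccc(Cl)cc2)s1` differs from compound 2 by propoxy in place of isopropyl on an aromatic carbon. Among the compounds with values here, no measured step covers this exchange; the one known step concerns a different group at the same carbon and was modest. No move beyond the scatter is expected for compound 3, estimated in this assay at 65% within 35% to 90%. The expected step is a number 2 percentage points higher from compound 2 to compound 3 (within the scatter).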

Compound 3, a percentage reported as inhibition, in the whole organism at one dose (the size of the read-out at that dose, not a potency): 63%
Compound 3: middle estimate off by 2 percentage points, on the high side, within the range that was stated.
By their numbers in this assay, from the lowest: compounds 2 and 3 (each within the scatter of the next); then compound 1.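

In this assay, propoxy in place of isopropyl on this aromatic carbon gives no change at the digits printed from compound 2 to compound 3 (within the scatter), so the entering oxygen, counted as a hydrogen-bond acceptor, goes with no step beyond the scatter here. Propoxy in place of chloro gives a number 26 percentage points lower from compound 1 to compound 3 (beyond the scatter), so both non-chloro groups shown now stand beyond the scatter from chloro. No measurement shown gives a reason for either result. From the compounds shown here alone, whether bromo, an amine or a carboxylic acid on this carbon would stand with chloro or with propoxy remains open, as does the result for a chain longer than propoxy.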